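Swapping an aromatic ring for a fluorinated saturated ring

A few compounds are considered here, and "the series" means these few. Any claim that something is new, unique, unknown or untested is made for them only; others in the source may bear on it.

In an ADME assay on MRC5 cells (Homo sapiens) for inhibition, with a stated time of 72 h (on this read-out lower numbers stand for an effect already at smaller amounts and higher numbers for an effect only at larger amounts of compound), compound 2 `CCc1ccccc1C(=O)Nc1c[nH]nc1C(=O)N[C@H]1CC[C@H](OC)CC1` gives 3400 nM; of the two numbers shown it stands together with compound 1, the two values lying within the scatter of each other. Compound 1 `CO[C@H]1CC[C@H](NC(=O)c2n[nH]cc2NC(=O)c2ccccc2C(F)(F)F)CC1` gives 3300 nM in this assay, and the step of a 1.0-fold higher number from compound 1 to compound 2 (0.01 log units; within the scatter) is within the scatter. Compound 3 `CCCCCNC(=O)c1n[nH]cc1NC(=O)c1c(OC)cccc1OC` reaches only a limit of this assay, > 50000 nM, which is the limit of > 50000 nM in this assay, at which 1 of the 3 values shown sits. Compound 4 `CO[C@H]1CC[C@H](NC(=O)c2n[nH]cc2NC(=O)C2CCC(F)(F)CC2)CC1` differs from compound 2 by 4,4-difluorocyclohexyl in place of 2-ethylphenyl on a carbonyl carbon. Among the compounds with values here, the one measured step exchanges a single substituent on an aromatic ring and does not speak to replacing the whole ring, so no measured step bears on this change. Compound 4 is expected to shift modestly toward higher numbers, a 1.8-fold higher number from compound 2 to compound 4 (0.25 log units; within the scatter), with an estimated value of 6000 nM in the range 2000 nM to 25000 nM.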

Compound 4, half-maximal effective concentration: > 50000 nM
Compound 4 ended at the assay's limit; the forecaster's own chance of this, stated with the estimate: 15%; at least 8.3-fold (0.92 log units) between middle value and limit.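

In this assay the whole-ring exchange at this carbonyl carbon gives an at least 14-fold higher number from compound 2 to compound 4 (1.16 log units; beyond the scatter), whereas the substituent exchange on the aromatic ring of compound 1 and compound 2 stayed within the scatter. This position therefore responds to replacing 2-ethylphenyl with 4,4-difluorocyclohexyl. From the compounds shown here alone, the reading for compound 4 is a limit and not a number, so the full size of the step stays unknown: the limit of > 50000 nM in this assay, at which 2 of the 4 values shown sit.

The compounds shown leave open whether the shift follows the saturated ring or its two fluorines, as plain cyclohexyl is not among them. Also open, going by these compounds, is how a pyridine ring would read on this carbonyl carbon.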